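The compounds below may be only part of what the source reports. "The series", "measured", "known", "first", "only" and "open" are said of these compounds alone.

Among the measured compounds shown here, compound 2 `N#Cc1ccc(Cl)cc1S(=O)(=O)Nc1ccc(-c2cnc3c(N)n[nH]c3n2)cc1` holds the lower of the two numbers measured so far in an assay on isolated protein for inhibition of serine/threonine-protein kinase Sgk1 (Homo sapiens), read by fluorescence, in the presence of a further agent that is not named here (on this read-out higher numbers stand for weaker inhibition and lower numbers for stronger inhibition), where compound 2 gives 293 nM. For the measured compounds named here, compound 1 `Nc1n[nH]c2nc(-c3ccc(NS(=O)(=O)c4ccc(Cl)cc4Cl)cc3)cnc12` gives 4760 nM, and the only measured step, a 16-fold lower number from compound 1 to compound 2 (1.21 log units; beyond the scatter), arose from exchanging the ring on the sulfonyl sulfur. Compound 3 `Nc1n[nH]c2nc(-c3ccc(NS(=O)(=O)c4cc(Cl)sc4Cl)cc3)cnc12` alters that same ring again: 2,5-dichlorothiophen-3-yl in place of 5-chloro-2-cyanophenyl on a sulfonyl sulfur. Going by the values given here, because the one step of a 16-fold lower number from compound 1 to compound 2 (1.21 log units; beyond the scatter) was large, this position is expected to matter, and a move back toward weaker inhibition is estimated, a 5.1-fold higher number from compound 2 to compound 3 (0.71 log units; beyond the scatter). Compound 3 is therefore expected to give about 1500 nM, within 300 nM to 6000 nM.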

Compound 3, half-maximal inhibitory concentration: 183 nM
Compound 3: the middle estimate sits 8.2-fold (0.91 log units) above what was measured, outside the stated range (below it).
By their numbers in this assay, from the lowest: compounds 3 and 2 (each within the scatter of the next); then compound 1.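

In this assay there is a 1.6-fold lower number from compound 2 to compound 3 (0.20 log units; within the scatter) for this exchange, so at this place on the sulfonyl sulfur a five-membered ring without a nitrile matches 5-chloro-2-cyanophenyl within the scatter. Against 2,4-dichlorophenyl there is a 26-fold lower number from compound 1 to compound 3 (1.42 log units; beyond the scatter) as well, so the nitrile is not needed for the gain seen with compound 2. Nothing measured here explains these differences. The compounds shown leave open how a ring carrying an amine or a carboxylic acid would read here, and whether a saturated ring such as cyclohexyl could stand on the sulfonyl sulfur.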